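Amine oxidase A inhibition: from compound 2 to compound 3

The compounds below may be only part of what the source reports. "The series", "measured", "known", "first", "only" and "open" are said of these compounds alone.

Compound 2 `NC(=O)COc1cc(=O)oc2cc(OCc3cccc(Cl)c3)ccc12` was measured in an assay on isolated protein (strain Sprague-Dawley) for inhibition of Amine oxidase [flavin-containing] A (Rattus norvegicus), read by spectrophotometry, with a stated time of 5 min (a lower number here means a stronger inhibitor, a higher number a weaker inhibitor), and gives 24000 nM, the higher of the two numbers in hand. Among the compounds with values here, its nearest neighbour is compound 1 `NC(=O)COc1cc(=O)oc2cc(OCc3cccc(Br)c3)ccc12`, which in this assay gives 8910 nM; the single measured step, a 2.7-fold higher number from compound 1 to compound 2 (0.43 log units; beyond the scatter), concerns only the halogen on the pendant aromatic ring.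

Compound 3 `Nc1cc(=O)oc2cc(OCc3cccc(Cl)c3)ccc12` differs from compound 2 at another place entirely: amino in place of carbamoylmethoxy on an aromatic carbon. Within the data shown here, no measured step touches this part of the shared core, so the halogen step from compound 1 to compound 2 gives no guidance on its direction or size. The account therefore rests on compound 2 alone. Compound 3 is expected to give a number in this assay close to that of compound 2, with the step of a 1.6-fold lower number from compound 2 to compound 3 (0.20 log units; within the scatter) taken as the central expectation, and with a wide range in both directions. The estimate for compound 3 in this assay is 15000 nM, expected to lie between 3000 nM and 80000 nM.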

Compound 3, half-maximal inhibitory concentration: 4170 nM
Beside the measured number, compound 3's estimate is 3.6-fold (0.56 log units) above it, within the range that was stated.
By their numbers in this assay, from the lowest: compound 3; then compound 1; then compound 2.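

In this assay, the change at this aromatic carbon, opposite the ring oxygen, gives a 5.8-fold lower number from compound 2 to compound 3 (0.76 log units; beyond the scatter). Within the data shown here, this is the first measured sign that this place on the shared core affects the number, since the earlier step, a 2.7-fold higher number from compound 1 to compound 2 (0.43 log units; beyond the scatter), concerned only the halogen on the pendant ring. With the chloro group held constant, the step also shows that the whole carbamoylmethoxy chain is not required here for inhibition to be measured, and that the much smaller amino group gives the lower number in this pair. No measured property or other finding accompanies this step, so the result stands without an explanation.

The compounds shown leave open whether the same change would give a similar step with bromo on the pendant ring, as this place has been varied only with chloro. They also do not show where a hydroxyl, a methoxy or a methylamino group at this place would fall relative to amino and carbamoylmethoxy, so a single pair cannot yet define a trend in the size or nature of the group.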